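Dimethoxy to Dimethyl on the Amide Aryl Ring

The source may report more compounds than this note shows. Statements on the series, on what has been measured and on what is new or still open speak of the compounds shown alone.

Compound 1 `Cc1cc(C(=O)N[C@H]2CCN(Cc3ccc(OCCCN(C)C)cc3)C2)ccc1Cl` and compound 2 `COc1ccc(C(=O)N[C@H]2CCN(Cc3ccc(OCCCN(C)C)cc3)C2)cc1OC` share one core. In an assay on HEK293 cells for binding affinity to Urotensin-2 receptor (Homo sapiens), read by radioligand binding (a lower number here means a stronger inhibitor, a higher number a weaker inhibitor), compound 1 gives 631 nM. For compound 2, this assay reports only a limit, < 10000 nM. The step that the limit leaves unreadable from compound 1 to compound 2 cannot be sized because of the limit of < 10000 nM in this assay, at which 1 of the 2 values shown sits. Compound 3 `Cc1ccc(C(=O)N[C@H]2CCN(Cc3ccc(OCCCN(C)C)cc3)C2)cc1C` differs from compound 2 by 3,4-dimethylphenyl in place of 3,4-dimethoxyphenyl on a carbonyl carbon. Going by the values given here, no measured step covers this change; compound 1, carrying 4-chloro-3-methylphenyl on the carbonyl carbon, gives 631 nM. Compound 3 is therefore expected near 1500 nM, estimated between 400 nM and 6000 nM. The expected step would be a step that the limit leaves unreadable from compound 2 to compound 3, toward stronger binding.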

Compound 3, inhibition constant: < 10000 nM
Compound 3: only a limit was reported; the forecaster's own chance of this, stated with the estimate: 15%; the middle value is on the limit's open side.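

No new step can be read among compound 1, compound 2 and compound 3, because compound 2 and compound 3 carry only limits: the limit of < 10000 nM in this assay, at which 2 of the 3 values shown sit. The compounds shown leave open how strongly compound 2 and compound 3 actually bind.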